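This account rests on a few compounds, and the source may have more. Where it says the series, first, only, none or still open, it means among the compounds named here.

Measured compounds:
Compound 1 `COc1ccc(/C=C/C(=O)c2ccc(OC)c(OC)c2)cc1` gives 97.2% in an ADME assay on RAW264.7 cells (Mus musculus) for cytotoxicity, read by MTT assay, with a stated time of 24 h, tested at 1.25 ug/mL; on this read-out higher numbers stand for a weaker effect at the one concentration tested and lower numbers for a stronger effect.
Compound 2 `COc1ccc(/C=C/C(=O)c2ccc(OC)c(OC)c2)cc1OC` gives 94% in this assay.

Among the compounds with values here, compound 2 stands next to compound 1, the only other measured compound, and the step of a number 3.2 percentage points lower from compound 1 to compound 2 (within the scatter) lies within the scatter. Compound 3 `COc1ccc(/C=C/C(=O)c2ccc(OC)c(OC)c2)cc1O` differs from compound 2 by hydrogen in place of methyl on an oxygen on an aromatic ring. Within the data shown here, no measured step concerns this change; the one step recorded, adding a methoxy on an aromatic carbon, was within the scatter. Compound 3 is therefore expected to stay close to compound 2, with an estimated step of a number 1 percentage points lower from compound 2 to compound 3 (within the scatter) that does not exceed the scatter. Compound 3 is estimated at 93%, between 78% and 100%.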

Compound 3, a percentage reported as activity, at one concentration (the size of the read-out at that concentration, not a potency): 91.4%
Beside the measured number, compound 3's estimate is 1.6 percentage points above it, within the range that was stated.
By their numbers in this assay, from the lowest: compounds 3, 2 and 1 (each within the scatter of the next).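

In this assay, methoxy to hydroxy on an oxygen on an aromatic ring gives a number 2.6 percentage points lower from compound 2 to compound 3 (within the scatter), so this position tolerates the loss of the methyl without a change beyond the scatter. Adding the hydroxy to the unsubstituted position gives a number 5.8 percentage points lower from compound 1 to compound 3 (within the scatter), so neither methoxy nor hydroxy here separates these compounds from the unsubstituted position. No evidence is available that bears on this result. Going by these compounds, whether an amine or a carboxylic acid would be tolerated on this aromatic carbon remains open, as does a longer chain on the oxygen. On these data alone, all three compounds also remain untested here at any other concentration.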